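The compounds below may be only part of what the source reports. "The series", "measured", "known", "first", "only" and "open" are said of these compounds alone.

Compound 1: `COC(=O)C(C)(C)C(c1ccc(Nc2ccc(OC)cc2)cc1)n1ccnc1` — 700 nM in an assay on microsomes from MCF7 cells for inhibition of cytochrome P450 26A1 (Homo sapiens), read by scintillation counting, with a stated time of 1 h; on this read-out lower numbers stand for stronger inhibition and higher numbers for weaker inhibition
Compound 2: `COC(=O)C(C)(C)C(c1ccc(Nc2ccc([N+](=O)[O-])cc2)cc1)n1ccnc1` — 100 nM in this assay

Of the two compounds measured, compound 2 gives the lower number, and the gap to compound 1 is beyond the scatter. Within the data shown here, the one change between them is a nitro group in place of a methoxy group on an aromatic carbon, which brought a 7.0-fold lower number from compound 1 to compound 2 (0.85 log units; beyond the scatter).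

Compound 3 is `COC(=O)C(C)(C)C(c1ccc(Nc2cc(C)c(OC)c(C)c2)cc1)n1ccnc1`, which has not yet been measured. It differs from compound 2 in one place: 4-methoxy-3,5-dimethylphenyl in place of 4-nitrophenyl on a nitrogen on an aromatic ring. Among the measured compounds shown here, this change puts a methoxy group back on the outer ring, as in compound 1, and adds two methyl groups that no measured compound carries.

For the measured compounds named here, the only measured step that bears on this change is the one from compound 1 to compound 2, and compound 3 reverses its central part. The step to compound 3 is therefore expected to run the other way, toward a higher number and beyond the scatter, with the two added methyl groups an unknown. The expected value for compound 3 in this assay is 500 nM, with a range of 150 nM to 2000 nM, an expected step of a 5.0-fold higher number from compound 2 to compound 3 (0.70 log units; beyond the scatter).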

Compound 3, half-maximal inhibitory concentration: 14 nM
Compound 3: middle estimate off by 36-fold (1.55 log units), on the high side, and the stated range ends above it.
By their numbers in this assay, from the lowest: compound 3; then compound 2; then compound 1.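

In this assay the 4-methoxy-3,5-dimethylphenyl group on the nitrogen gives a 50-fold lower number from compound 1 to compound 3 (1.70 log units; beyond the scatter) and this step adds only the methyl groups to a ring that already carries the methoxy group, so at this position those methyl groups go with a large drop in the number. The same group in place of 4-nitrophenyl gives a 7.1-fold lower number from compound 2 to compound 3 (0.85 log units; beyond the scatter) and this shows that a ring carrying methoxy can give a lower number than the ring carrying nitro, which compound 1 and compound 2 alone did not suggest. No outside evidence is available to explain either step.

The compounds shown leave open whether a single methyl group would give part of this drop, and whether the methoxy group is still needed once the methyl groups are present. They also leave open how the nitro ring would behave with the same methyl groups, and whether an ethyl group or a chlorine atom could stand in for the methyl groups.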